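The source may hold more compounds than are shown below. What is called first, only, known or untested is meant among the compounds shown, and "the series" means these compounds.

Measured so far:
compound 1, `O=C(/C=C/C(=O)N1C/C(=C\c2ccccc2)C(=O)/C(=C/c2ccccc2)C1)Nc1ccc([N+](=O)[O-])cc1` — 40000 nM
compound 2, `Cc1ccc(NC(=O)/C=C/C(=O)N2C/C(=C\c3ccc([N+](=O)[O-])cc3)C(=O)/C(=C/c3ccc([N+](=O)[O-])cc3)C2)cc1C` — 700 nM

In a functional assay on CCRF-CEM cells (Homo sapiens) for cytotoxicity (a lower number here means a stronger inhibitor, a higher number a weaker inhibitor), compound 1 gives 40000 nM, the highest of the two numbers shown; compound 2 gives 700 nM, and these two differ in two places, so the gap cannot be laid to one change. Compound 3, `Cc1ccc(NC(=O)/C=C/C(=O)N2C/C(=C\c3ccccc3)C(=O)/C(=C/c3ccccc3)C2)cc1C`, differs from compound 1 in one place only: 3,4-dimethylphenyl in place of 4-nitrophenyl on an amide-type nitrogen. Going by the values given here, no single step for this change has been measured. Given the lower number of compound 2, a downward step from compound 1 to compound 3 is expected, estimated at a 5.0-fold lower number from compound 1 to compound 3 (0.70 log units; beyond the scatter), though of uncertain size. For compound 3 the expected value is 8000 nM, within 1500 nM to 40000 nM.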

Compound 3, half-maximal inhibitory concentration: 7100 nM
Beside the measured number, compound 3's estimate is 1.1-fold (0.05 log units) above it; measured number inside the range.
By their numbers in this assay, from the lowest: compound 2; then compound 3; then compound 1.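

In this assay, the amide-type nitrogen now has a single change on record: 3,4-dimethylphenyl in place of 4-nitrophenyl gives a 5.6-fold lower number from compound 1 to compound 3 (0.75 log units; beyond the scatter), with the shared core unchanged. This shows that the group at this position alone moves the number beyond the scatter, which compound 1 and compound 2 could not show. Nothing in hand offers a reason for the step. On these data alone, whether the step keeps its size on the core of compound 2 stays open, as does how an unsubstituted phenyl, a 4-methoxyphenyl or a 4-carboxyphenyl group would read on that nitrogen.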